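Restoring a Carbonyl Arm on a Shared Thioether Core

The compounds below may be only part of what the source reports. "The series", "measured", "known", "first", "only" and "open" are said of these compounds alone.

Compound 2 `COc1cc(-c2nnc(SCc3ccccc3)n2N2C(=O)c3ccccc3C2=O)cc(OC)c1OC` reaches only a limit of the test in a functional assay on A549 cells (Homo sapiens) for cytotoxicity, read by MTT assay, with a stated time of 48 h (on this read-out lower numbers stand for stronger inhibition and higher numbers for weaker inhibition), namely > 200000 nM. Compound 3 `COc1cc(-c2nnc(SCC(=O)c3ccccc3C)n2N2C(=O)c3ccccc3C2=O)cc(OC)c1OC` differs from it by (2-methylphenyl)carbonyl in place of phenyl on a saturated chain carbon bound to a sulfur. Going by the values given here, one measured step bears on this change: compound 1 `COc1cc(-c2nnc(SCC(=O)c3ccc(Cl)cc3)n2N2C(=O)c3ccccc3C2=O)cc(OC)c1OC`, which in this assay gives 9030 nM, shows an at least 22-fold higher number from compound 1 to compound 2 (1.34 log units; beyond the scatter) when its carbonyl-bearing arm is cut back to a bare phenyl, the cut compound sitting at the limit of > 200000 nM in this assay, at which 1 of the 2 values shown sits. Putting a carbonyl arm back is therefore expected to lower the number strongly, so compound 3 is estimated at 15000 nM, ranging from 4000 nM to 70000 nM. This corresponds to an expected step of an at least 13-fold lower number from compound 2 to compound 3 (1.12 log units; beyond the scatter).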

Compound 3, half-maximal inhibitory concentration: 144000 nM
For compound 3 the middle estimate is 9.6-fold (0.98 log units) below the measured one, outside the stated range (above it).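

In this assay a carbonyl arm alone does not ensure a low number, as the small readable change shows: an at least 1.3-fold lower number from compound 2 to compound 3 (0.14 log units; that floor lies within the scatter) and no more can be said. The value of compound 2 is only a limit of the test: the limit of > 200000 nM in this assay, at which 1 of the 3 values shown sits. The group on the carbonyl carbon counts heavily, with 2-methylphenyl in place of 4-chlorophenyl giving a 16-fold higher number from compound 1 to compound 3 (1.20 log units; beyond the scatter) on an otherwise identical compound.

Still open, on these data alone, is whether the chlorine itself or its place on the ring matters, as these two rings differ in both. As far as these compounds go, how an amine or a carboxylic acid on that ring would read also remains unknown.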